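A few compounds are considered here, and "the series" means these few. Any claim that something is new, unique, unknown or untested is made for them only; others in the source may bear on it.

Measured compounds:
compound 1 `COc1cc(Oc2cccc(Nc3ccccc3)c2)cc(OC)c1CNCc1ccccc1` — 3340 nM
compound 2 `COc1cc(Oc2cccc(Nc3ccccc3)c2)cc(OC)c1CNCc1ccc(O)cc1` — 2180 nM

In a functional assay on HT-29 cells (Homo sapiens) for inhibition, read by MTT assay, with a stated time of 72 h (a higher number here means a weaker inhibitor, a lower number a stronger inhibitor), compound 1 gives 3340 nM. Among the two numbers measured, compound 1 has the highest, and its only neighbour is compound 2, which in this assay gives 2180 nM; the step of a 1.5-fold lower number from compound 1 to compound 2 (0.19 log units; within the scatter) lies within the scatter, so the two compounds cannot be ordered against each other on these numbers.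

Compound 3 `COc1cc(Oc2cccc(Nc3ccccc3)c2)cc(OC)c1CNCc1ccc(Br)cc1` has not yet been measured. It differs from compound 1 in one place: bromo in place of hydrogen on an aromatic carbon. Among the compounds with values here, the single measured step, from compound 1 to compound 2, also places a new group on an aromatic carbon of the benzyl part and did not move the number beyond the scatter. Within the data shown here, no measured step involves a bromo group, so nothing in the data points to a shift in either direction for compound 3. The expectation is therefore a step no larger than the scatter, estimated as a 1.1-fold lower number from compound 1 to compound 3 (0.05 log units; within the scatter). For compound 3 the estimated value in this assay is 3000 nM, with a range from 1400 nM to 6500 nM.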

Compound 3, half-maximal inhibitory concentration: 3060 nM
Compound 3: the middle estimate sits 1.0-fold (0.01 log units) below what was measured; the measured number falls inside the stated range.
By their numbers in this assay, from the lowest: compounds 2, 3 and 1 (each within the scatter of the next).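

In this assay, bromo in place of hydrogen on this aromatic carbon, para to a large group, gives a 1.1-fold lower number from compound 1 to compound 3 (0.04 log units; within the scatter), and bromo in place of hydroxy at the same carbon gives a 1.4-fold higher number from compound 2 to compound 3 (0.15 log units; within the scatter). Where the earlier pair offered only one substituent against hydrogen, this place now carries three different occupants, hydrogen, hydroxy and bromo, and every step among them stays within the scatter, including the step to a group with 0 hydrogen-bond donors and 0 hydrogen-bond acceptors, so the three compounds cannot be ordered against each other. Nothing available explains why the numbers stay so close together.

The compounds shown do not tell whether a group of another kind at this place, such as an amine, a carboxylic acid or a longer chain, would move the number beyond the scatter. They also leave open whether bromo on a different carbon of this ring, or any change to the shared core of compound 1, would move the number in this cell assay.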